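The compounds below may be only part of what the source reports. "The series", "measured", "known", "first", "only" and "open" are said of these compounds alone.

Working notes on the trimethoxyphenyl-pyrazole enone series. Compound 1 `COc1cc(-c2cc(/C=C/C(=O)c3ccc(N)cc3)[nH]n2)cc(OC)c1OC` gives 6000 nM in a functional assay on UO-31 cells (Homo sapiens) for inhibition, read by sulforhodamine B assay, with a stated time of 48 h; a higher number here means that more compound is tolerated, a lower number that less compound is tolerated. Compound 2 `COc1cc(-c2cc(/C=C/C(=O)c3ccc(Cl)c(Cl)c3)[nH]n2)cc(OC)c1OC` reaches only the assay limit, > 100000 nM (the limit of > 100000 nM in this assay, at which 1 of the 3 values shown sits). Compound 3 `COc1ccc(C(=O)/C=C/c2cc(-c3cc(OC)c(OC)c(OC)c3)n[nH]2)cc1OC` gives 5170 nM in this assay. Of the two values that are numbers rather than limits, compound 3 stands together with compound 1: a 1.2-fold lower number from compound 1 to compound 3 (0.06 log units; within the scatter), so the swap of 3,4-dimethoxyphenyl for 4-aminophenyl on the carbonyl carbon did not move the number. The dichlorophenyl analogue behaves differently: an at least 16-fold higher number from compound 1 to compound 2 (1.22 log units; beyond the scatter) and an at least 19-fold lower number from compound 2 to compound 3 (1.28 log units; beyond the scatter).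

Compound 4 `COc1ccc(C(=O)/C=C/c2cc(-c3cc(OC)c(OC)c(OC)c3)n[nH]2)cc1` removes one methoxy: hydrogen in place of methoxy on an aromatic carbon. Within the data shown here, no measured step trims a methoxy from the aryl ring on the carbonyl carbon; the only change that kept a methoxy-bearing ring, from compound 1 to compound 3, sat within the scatter, while the large shift arose only with dichlorophenyl. The 4-methoxyphenyl of compound 4 therefore is expected to sit near compound 3, with no step beyond the scatter anticipated: a 1.3-fold higher number from compound 3 to compound 4 (0.10 log units; within the scatter). Compound 4 is thus estimated at 6500 nM, in the range 2500 nM to 18000 nM, in this assay.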

Compound 4, concentration lethal to 50% of the cells: 5590 nM
Compound 4: the middle estimate sits 1.2-fold (0.07 log units) above what was measured, and the stated range covers the measured number.
By their numbers in this assay, from the lowest: compounds 3, 4 and 1 (each within the scatter of the next). At a limit, above all of these: compound 2.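

On the aryl ring at the carbonyl carbon, going from 3,4-dimethoxyphenyl to 4-methoxyphenyl leaves the number in this assay unmoved, with a 1.1-fold higher number from compound 3 to compound 4 (0.03 log units; within the scatter), and the single methoxy does not separate from the amino group either, with a 1.1-fold lower number from compound 1 to compound 4 (0.03 log units; within the scatter). Three aryl rings bearing methoxy or amino groups therefore read alike, while the 3,4-dichlorophenyl ring alone stands apart, with an at least 17-fold lower number from compound 2 to compound 4 (1.25 log units; beyond the scatter). The value of compound 2 is a limit: the limit of > 100000 nM in this assay, at which 1 of the 4 values shown sits.

Open, on these data alone, is how a single chlorine, a hydroxyl or a carboxylic acid on this ring would read, and so whether the separation of compound 2 goes with one chlorine or needs both. Also open, as far as these compounds go, is how the number responds to a change on the trimethoxyphenyl ring, for example an ethoxy in place of a methoxy.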